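A Saturated Ring Replaces the Imidazole Amide

The compounds below may be only part of what the source reports. "The series", "measured", "known", "first", "only" and "open" are said of these compounds alone.

The series shares one core, carrying an acylated amino group whose acyl part is varied. Compound 1, `COc1cc(C(N)=O)cc2nc(NC(=O)c3ccc4ccccc4n3)n(CCCNC(=O)OCc3ccccc3)c12`, bears a quinolin-2-yl on that carbonyl carbon. In an assay for activation of interferon regulatory factor 3 (Homo sapiens), read by a luciferase reporter, with a stated time of 20 h (a lower number here means that less compound is needed, a higher number that more compound is needed for the effect), compound 1 reaches only the limit of the measurement, > 100000 nM. Compound 2, `COc1cc(C(N)=O)cc2nc(NC(=O)c3cncn3C)n(CCCNC(=O)OCc3ccccc3)c12`, carries 1-methyl-1H-imidazol-5-yl in its place. In this assay compound 2 likewise reaches only a limit, > 100000 nM. The step that the two limits leave unreadable from compound 1 to compound 2 therefore cannot be read; both compounds sit at the limit of > 100000 nM in this assay, at which 2 of the 2 values shown sit.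

Compound 3, `COc1cc(C(N)=O)cc2nc(NC(=O)C3CCCN3C)n(CCCNC(=O)OCc3ccccc3)c12`, differs from compound 2 by 1-methylpyrrolidin-2-yl in place of 1-methyl-1H-imidazol-5-yl on a carbonyl carbon. For the measured compounds named here, the only measured step at this position gives no usable size, so no direction can be drawn from it; what the two values show is that neither aryl amide produced a measurable response in this assay. With both measured neighbours at the limit, compound 3 is expected to behave in the same way, and the expected step of a number no higher from compound 2 to compound 3 (the limit leaves the size open) is none that can be resolved. For compound 3 the estimate in this assay is 100000 nM, within 30000 nM to 300000 nM, most likely again reported only as a limit.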

Compound 3, half-maximal effective concentration: > 100000 nM
Compound 3: only a limit was reported (the forecaster's own chance of this, stated with the estimate: 80%); the middle value lies on the limit itself.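

Compound 3 also gives only a limit in this assay, so the steps linking compound 1, compound 2 and compound 3 cannot be read, and neither size nor direction follows for any of them: the limit of > 100000 nM in this assay, at which 3 of the 3 values shown sit.

The compounds shown leave open whether any acyl group on the shared core gives a measurable response in this assay.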